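The source may report more compounds than this note shows. Statements on the series, on what has been measured and on what is new or still open speak of the compounds shown alone.

Measured so far in a functional assay on HCT-116 cells (Homo sapiens) for inhibition, read by MTT assay, with a stated time of 72 h; a lower number here means a stronger inhibitor, a higher number a weaker inhibitor:
- compound 1 `O=C(Nc1ccccc1)c1ccc(/N=N\c2c[nH]c3ccccc23)cc1`: 103000 nM
- compound 2 `Cc1ccc(NC(=O)c2ccc(/N=N\c3c[nH]c4ccccc34)cc2)c(C)c1`: 76100 nM

Compound 2 gives the lower of the two numbers, but the step of a 1.4-fold lower number from compound 1 to compound 2 (0.13 log units; within the scatter) is within the scatter, so compounds 1 and 2 cannot be told apart in this assay. Both carry the same core and differ only in the group on the amide-type nitrogen.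

Compound 3 `O=C(Nc1cccc(Cl)c1)c1ccc(/N=N\c2c[nH]c3ccccc23)cc1` is the next member of the series. It differs from compound 2 by 3-chlorophenyl in place of 2,4-dimethylphenyl on an amide-type nitrogen. Among the measured compounds shown here, the one step measured so far, a 1.4-fold lower number from compound 1 to compound 2 (0.13 log units; within the scatter), also exchanged the group on that amide-type nitrogen and produced no change beyond the scatter. For the measured compounds named here, no measured pair bears on a chlorine substituent on that ring, so the expectation rests on that single step and on the shared core alone. The expected step in this assay from compound 2 to compound 3 is therefore none beyond the scatter, a 1.1-fold higher number from compound 2 to compound 3 (0.05 log units; within the scatter), with wide uncertainty in both directions.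

Compound 3 is estimated at 85000 nM, expected to lie between 30000 nM and 250000 nM.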

Compound 3, half-maximal inhibitory concentration: 80000 nM
Compound 3: the middle estimate sits 1.1-fold (0.03 log units) above what was measured; measured number inside the range.
By their numbers in this assay, from the lowest: compounds 2, 3 and 1 (each within the scatter of the next).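

In this assay the 3-chlorophenyl group gives a second exchange on the amide-type nitrogen that stays within the scatter, with a 1.1-fold higher number from compound 2 to compound 3 (0.02 log units; within the scatter) as the step from the 2,4-dimethylphenyl compound. The series now also holds a change of a single substituent on this ring, chloro in place of hydrogen on an aromatic carbon, and that step too stays within the scatter, at a 1.3-fold lower number from compound 1 to compound 3 (0.11 log units; within the scatter). Phenyl, 2,4-dimethylphenyl and 3-chlorophenyl on this nitrogen therefore cannot be told apart in this assay, and no measurement at hand offers an explanation for this.

From the compounds shown here alone, whether any substituent on this ring can move the number beyond the scatter stays open, for example an amine or a carboxylic acid in place of the methyl and chloro groups seen so far. Also open, going by these compounds, is whether a longer chain in place of the aromatic ring on the amide-type nitrogen, or a change in the shared core itself, would produce a step larger than the scatter.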